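Working notes: saturated chain carbon substituent on the shared core

The compounds below may be only part of what the source reports. "The series", "measured", "known", "first", "only" and "open" are said of these compounds alone.

Compound 3 `CC(C)(N)C(=O)N[C@H](COCc1ccccc1)c1nnnn1CC#N` gives 29 nM in a functional assay on H4 cells for agonist activity at growth hormone secretagogue receptor type 1 (Homo sapiens), read by FLIPR (a lower number here means that less compound is needed, a higher number that more compound is needed for the effect), the second highest of the three numbers measured. Compound 2 `CC(C)(N)C(=O)N[C@H](COCc1ccccc1)c1nnnn1CCCc1ccccc1` gives 17 nM, and the pair reads as a 1.7-fold higher number from compound 2 to compound 3 (0.23 log units; within the scatter). Going by the values given here, compound 1 `CC(C)(N)C(=O)N[C@H](COCc1ccccc1)c1nnnn1Cc1ccc(NS(C)(=O)=O)cc1` gives 259 nM, with an 8.9-fold lower number from compound 1 to compound 3 (0.95 log units; beyond the scatter) and a 15-fold lower number from compound 1 to compound 2 (1.18 log units; beyond the scatter) the only steps beyond the scatter. Compound 4 `CCCCNC(=O)CCn1nnnc1[C@@H](COCc1ccccc1)NC(=O)C(C)(C)N` differs from compound 3 as follows: (butylcarbamoyl)methyl in place of cyano on a saturated chain carbon bound to an aromatic nitrogen. The steps bearing on this change are a 1.7-fold higher number from compound 2 to compound 3 (0.23 log units; within the scatter) and an 8.9-fold lower number from compound 1 to compound 3 (0.95 log units; beyond the scatter): two quite different groups at this place give near-identical numbers, while the third gives a clearly higher one. A small rise, within or just beyond the scatter, is therefore expected for compound 4. The expected step is a 1.6-fold higher number from compound 3 to compound 4 (0.19 log units; within the scatter). Compound 4 is estimated at 45 nM, range 15 nM to 140 nM.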

Compound 4, half-maximal effective concentration: 42 nM
Compound 4: the middle estimate sits 1.1-fold (0.03 log units) above what was measured; the range from low to high includes it.
By their numbers in this assay, from the lowest: compounds 2, 3 and 4 (each within the scatter of the next, the first and the last beyond it); then compound 1.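

Replacing cyano with (butylcarbamoyl)methyl, on a saturated chain carbon bound to an aromatic nitrogen, shows that this position in this assay also takes a longer chain carrying an amide (a 1.4-fold higher number from compound 3 to compound 4 (0.16 log units; within the scatter)). Butylcarbamoyl in place of benzyl gives the first step beyond the scatter among compounds without the 4-(methanesulfonamido)phenyl group (a 2.5-fold higher number from compound 2 to compound 4 (0.39 log units; beyond the scatter)). The gap to that group also remains beyond the scatter (a 6.2-fold lower number from compound 1 to compound 4 (0.79 log units; beyond the scatter)), and no supporting evidence accounts for these steps.

Open, from the compounds shown here alone, is how a carboxylic acid or a primary amine in place of the butylcarbamoyl group would read. Also open, going by these compounds, is whether a longer chain without the amide would match compound 2.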